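The source may report more compounds than this note shows. Statements on the series, on what has been measured and on what is new or still open speak of the compounds shown alone.

Three compounds share a core. Compound 1 `Cc1cccc(CNc2ncnc3c2ncn3[C@@H]2O[C@H](CO)[C@@H](O)[C@H]2O)c1` gives in a functional assay on MCF cells (Homo sapiens) for antiproliferative activity, with a stated time of 72 h (a higher number here means a weaker inhibitor, a lower number a stronger inhibitor), only a limit, > 166000 nM. Compound 2 `Cc1ccc(CNc2ncnc3c2ncn3[C@@H]2O[C@H](CO)[C@@H](O)[C@H]2O)cc1` gives in this assay likewise a limit, > 166000 nM. Compound 3 `OC[C@H]1O[C@@H](n2cnc3c(NCc4cc(F)cc(F)c4)ncnc32)C(O)C1O` gives in this assay also a limit, > 166000 nM. The step that the two limits leave unreadable from compound 1 to compound 2 is therefore not readable in size or direction. Compound 2 thus stands at the limit of > 166000 nM in this assay, at which 3 of the 3 values shown sit, with no numerical value of its own.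

Compound 4 `OC[C@H]1O[C@@H](n2cnc3c(NCc4ccc(F)c(F)c4F)ncnc32)[C@H](O)[C@@H]1O` carries the next change: 2,3,4-trifluorophenyl in place of 4-methylphenyl on a saturated chain carbon bound to a nitrogen on an aromatic ring. Going by the values given here, no measured step bears on this change; the only step between measured compounds is unreadable. With every value shown at the same limit, compound 4 is expected to give in this assay an estimate of 200000 nM, ranging from 80000 nM to 500000 nM, and most probably again only a limit. The estimated step that the limit leaves unreadable from compound 2 to compound 4 is expected to be none beyond the scatter.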

Compound 4, half-maximal inhibitory concentration: > 166000 nM
Compound 4: a limit, no number (the forecaster's own chance of this, stated with the estimate: 85%); the middle value does not contradict the limit.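

In this assay, going by these compounds alone, compound 4 gives > 166000 nM, a limit and not a number, so no step linking it to compound 1 or compound 2 can be read. The compounds shown leave open whether any group at this place gives a measurable value: the limit of > 166000 nM in this assay, at which 4 of the 4 values shown sit.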